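This account rests on a few compounds, and the source may have more. Where it says the series, first, only, none or still open, it means among the compounds named here.

Measured so far in a physicochemical assay for lipophilicity; a higher number here means a more lipophilic compound, a lower number a more polar compound:
compound 1, `CNc1ccc(-c2nc3ccc(O)cc3s2)cn1`, gives 1.8
compound 2, `CNc1ccc(-c2nc3ccc(OC)cc3s2)cn1`, gives 3.2
compound 3, `COc1ccc2nc(-c3ccc(N(C)C)nc3)oc2c1`, gives 3.7

Compounds 1 and 2 share a core and differ in one place: hydrogen in place of methyl on an oxygen on an aromatic ring. This change made a step of a number 1.40 log units lower from compound 2 to compound 1 (beyond the scatter). Compound 3 has a different core; the difference between the two cores is not broken down here, and compound 3 gives the highest number of the three. Compound 4, `CN(C)c1ccc(-c2nc3ccc(O)cc3o2)cn1`, has not yet been measured in this assay. It stands to compound 3 as compound 1 stands to compound 2: hydrogen in place of methyl on an oxygen on an aromatic ring. The place of the change reads the same in both pairs, so it is the same change. Compound 4 is therefore expected to take a step of a number 1.40 log units lower from compound 3 to compound 4 (beyond the scatter), an expectation that rests on the earlier step of a number 1.40 log units lower from compound 2 to compound 1 (beyond the scatter). Compound 4 is estimated at 2.3, most likely between 1.8 and 2.8.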

Compound 4, distribution coefficient: 1.9
The estimate for compound 4 lay 0.40 log units above the measured number; measured number inside the range.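

In this assay the change from methoxy to hydroxy gives a number 1.80 log units lower from compound 3 to compound 4 (beyond the scatter) on one core and a number 1.40 log units lower from compound 2 to compound 1 (beyond the scatter) on the other core, so the direction carried over and both steps are large. A step measured on one core was therefore a useful guide to the step on the other. Within the data shown here, this rests on only two pairs and shows nothing about cores beyond these two, and no measurement here explains the result.

The compounds shown leave open whether the step would hold on a third core. They also leave open what would happen if the hydroxy gave way to an amine or a carboxylic acid, or the methyl to a longer chain.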